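Chain length between the ether oxygen and the amine

This account rests on a few compounds, and the source may have more. Where it says the series, first, only, none or still open, it means among the compounds named here.

The shared core carries a basic amine on a saturated chain joined through an oxygen on an aromatic ring. In an assay on isolated protein (Cavia porcellus) with Sigma non-opioid intracellular receptor 1 (Homo sapiens) as the target, read by radioligand binding (a lower number here means a stronger inhibitor, a higher number a weaker inhibitor), compound 1 `CN(C)CCCCCCOc1ccc2oc(-c3ccccc3)cc(=O)c2c1` gives 335 nM. Compound 2 `CN(C)CCCCCCCCOc1ccc2oc(-c3ccccc3)cc(=O)c2c1` gives 143 nM in this assay, showing a 2.3-fold lower number from compound 1 to compound 2 (0.37 log units; beyond the scatter). Compound 3 `O=c1cc(-c2ccccc2)oc2ccc(OCCCN3CCC(O)CC3)cc12` gives 123 nM in this assay, the lowest of the three numbers, with a 1.2-fold lower number from compound 2 to compound 3 (0.07 log units; within the scatter) and a 2.7-fold lower number from compound 1 to compound 3 (0.44 log units; beyond the scatter). Compound 4 `O=c1cc(-c2ccccc2)oc2ccc(OCCCCCCN3CCC(O)CC3)cc12` is not yet measured; it differs from compound 3 by 3-(4-hydroxypiperidin-1-yl)propyl in place of 4-hydroxypiperidin-1-yl on a saturated chain carbon, three bonds along the chain from an oxygen on an aromatic ring. The measured step that bears on it most directly is the lengthening of the chain seen in a 2.3-fold lower number from compound 1 to compound 2 (0.37 log units; beyond the scatter), a modest lowering; the step of a 2.7-fold lower number from compound 1 to compound 3 (0.44 log units; beyond the scatter) mixes a shorter chain with a different amine and so says less about chain length on its own. A modest lowering in this assay is therefore expected for compound 4, namely a 2.1-fold lower number from compound 3 to compound 4 (0.31 log units; beyond the scatter). Compound 4 is estimated at 60 nM, within a range of 20 nM to 180 nM.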

Compound 4, half-maximal inhibitory concentration: 121 nM
Compound 4: middle estimate off by 2.0-fold (0.30 log units), on the low side; measured number inside the range.
By their numbers in this assay, from the lowest: compounds 4, 3 and 2 (each within the scatter of the next); then compound 1.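

With 4-hydroxypiperidin-1-yl as the amine, the longer chain gives a 1.0-fold lower number from compound 3 to compound 4 (0.01 log units; within the scatter) in this assay, so the lowering seen with dimethylamino does not appear with this amine. Within the data shown here, on the chain shared by the two compounds, 4-hydroxypiperidin-1-yl in place of dimethylamino gives a 2.8-fold lower number from compound 1 to compound 4 (0.44 log units; beyond the scatter) as the first reading of the amine alone, and this step is beyond the scatter. The remaining comparison, a 1.2-fold lower number from compound 2 to compound 4 (0.07 log units; within the scatter) between compounds that differ in both chain and amine, leaves those two indistinguishable in this measurement.

Nothing available accounts for why chain length registers with one amine and not with the other. Going by these compounds, whether a still longer chain, a piperidine without the hydroxyl, or a morpholine would stay level with compound 3 and compound 4 remains open.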